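A few compounds are considered here, and "the series" means these few. Any claim that something is new, unique, unknown or untested is made for them only; others in the source may bear on it.

Of the compounds shown here, three have numbers so far in an ADME assay on microsomes from liver (Rattus norvegicus) for metabolic stability, read by LC-MS, using NADPH, with a stated time of 30 min, tested at 1 uM; a higher number here means faster removal of the compound, a lower number slower removal. Compound 1 `CCc1cnc(N2CCC(C(C)COC(=O)N3CCc4cc(S(C)(=O)=O)cc(F)c43)CC2)nc1` gives 365 mL.min-1.g-1, compound 2 `CC(C)c1noc(N2CCC(Oc3cc(N4CCc5cc(N6CCCNS6(=O)=O)ccc54)ncn3)CC2)n1` gives 21 mL.min-1.g-1, and compound 3 `CC(C)c1noc(N2CCC(Oc3cc(N4CCc5cc(N6CC(O)CCC6=O)ccc54)ncn3)CC2)n1` gives 7 mL.min-1.g-1. Compound 3 is therefore the lowest of the three, beyond the scatter from both of the others.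

The next compound is compound 4 `CC(C)c1noc(N2CCC(Oc3cc(N4CCc5cc(N6CCOCC6=O)ccc54)ncn3)CC2)n1`, which differs from compound 3 at one place: 3-oxomorpholin-4-yl in place of 5-hydroxy-2-oxopiperidin-1-yl on an aromatic carbon. Among the compounds with values here, one measured step bears on this change: a 3.0-fold lower number from compound 2 to compound 3 (0.48 log units; beyond the scatter). That step is modest but beyond the scatter, and it also exchanges one six-membered non-aromatic ring for another on an aromatic carbon. Within the data shown here, compound 1 differs from the others in more than one place, so it offers no step at this position. Among the measured compounds shown here, no measured compound carries the 3-oxomorpholin-4-yl group, and a single step gives no firm direction for it.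

In this assay, a small rise is tentatively expected, smaller than the measured step of a 3.0-fold lower number from compound 2 to compound 3 (0.48 log units; beyond the scatter) and not beyond the scatter. The expected step is a 1.6-fold higher number from compound 3 to compound 4 (0.20 log units; within the scatter). For compound 4 the estimated value is 11 mL.min-1.g-1, with an expected range of 5 mL.min-1.g-1 to 25 mL.min-1.g-1.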

Compound 4, intrinsic clearance in microsomes: 46 mL.min-1.g-1
For compound 4 the middle estimate is 4.2-fold (0.62 log units) below the measured one, outside the stated range (above it).
By their numbers in this assay, from the lowest: compound 3; then compound 2; then compound 4; then compound 1.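

At this position, on an aromatic carbon meta to a fused ring and para to a fused ring, the lactam-type ring exchange is not a small adjustment in this assay: 3-oxomorpholin-4-yl in place of 5-hydroxy-2-oxopiperidin-1-yl gives a 6.6-fold higher number from compound 3 to compound 4 (0.82 log units; beyond the scatter), and the same group in place of the sulfur-containing ring gives a 2.2-fold higher number from compound 2 to compound 4 (0.34 log units; beyond the scatter). The three groups now fall into a single order on the shared core, with 5-hydroxy-2-oxopiperidin-1-yl lowest, the sulfur-containing ring in the middle and 3-oxomorpholin-4-yl highest, so the position is sensitive to the ring's make-up even at nearly constant size. No measurement offered here accounts for this order.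

The step from 5-hydroxy-2-oxopiperidin-1-yl to 3-oxomorpholin-4-yl removes the hydrogen-bond donor and adds a ring oxygen at once, so the two changes cannot be told apart on these compounds. As far as these compounds go, the plain 2-oxopiperidin-1-yl ring, without the hydroxyl, would separate them, and how an open-chain amide or an amine would behave at this position remains unknown.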